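Swapping an Acid for a Dimethylamide on a Shared Core

The source may hold more compounds than are shown below. What is called first, only, known or untested is meant among the compounds shown, and "the series" means these compounds.

Measured in a functional assay on HEK293 cells (Homo sapiens), read by cAMP accumulation; a lower number here means that less compound is needed, a higher number that more compound is needed for the effect:
compound 1 `CCCC1=C(C(=O)OCc2ccc(C(=O)O)cc2)C(c2cccc(C)c2)NC(=O)N1` gives 3400 nM
compound 2 `CCCC1=C(C(=O)OCC)C(c2cccc(Cl)c2)NC(=O)N1` gives 6800 nM

Compound 1 carries the lower of the two numbers, yet its gap to compound 2 lies within the usual scatter, so the two cannot be ranked against each other. Compound 3 `CCCC1=C(C(=O)OCc2ccc(C(=O)N(C)C)cc2)C(c2cccc(C)c2)NC(=O)N1` differs from compound 1 in one place: dimethylamino in place of hydroxy on a carbonyl carbon. For the measured compounds named here, no step between measured compounds covers this kind of change, so its direction is open. The expected shift in this assay is a 1.2-fold higher number from compound 1 to compound 3 (0.07 log units; within the scatter), a step no larger than the scatter. Compound 3 is therefore estimated at 4000 nM, with a range from 1000 nM to 15000 nM.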

Compound 3, half-maximal effective concentration: 3400 nM
Compound 3: middle estimate off by 1.2-fold (0.07 log units), on the high side; the measured number falls inside the stated range.
By their numbers in this assay, from the lowest: compounds 1, 3 and 2 (each within the scatter of the next).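

At this carbonyl carbon, this assay gives no change at the digits printed from compound 1 to compound 3 (within the scatter) when dimethylamino takes the place of hydroxy. The swap removes a hydrogen-bond donor and brings in a larger group, yet the read-out does not separate the carboxy and dimethylcarbamoyl compounds, so this position tolerates at least this one change. Nothing available explains this match.

From the compounds shown here alone, whether a primary amide, a methyl ester or a ring amide such as a morpholine amide would also leave the number in place remains open.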